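Compound 3 to compound 4: carboxy leaves, 4-fluorophenyl enters

This account rests on a few compounds, and the source may have more. Where it says the series, first, only, none or still open, it means among the compounds named here.

In a functional assay on NALM-6 cells (Homo sapiens) for cytotoxicity, with a stated time of 72 h (on this read-out lower numbers stand for an effect already at smaller amounts and higher numbers for an effect only at larger amounts of compound), compound 3 `C=C[C@@](C)(/C=C/c1ccc(O)c(/C=C/C(=O)O)c1)CCC=C(C)C` shows only a limit (> 43400 nM). Compound 2 `C=C[C@@](C)(/C=C/c1ccc(O)c(/C=C/C#N)c1)CCC=C(C)C` also shows only a limit (> 43400 nM). Compound 1 `C=C[C@@](C)(/C=C/c1ccc(O)c(/C=C/C(=O)c2ccccc2)c1)CCC=C(C)C` gives a measured number (4470 nM) and carries a benzoyl group in the place that changes here.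

Compound 4 `C=C[C@@](C)(/C=C/c1ccc(O)c(/C=C/c2ccc(F)cc2)c1)CCC=C(C)C` differs from compound 3 as follows: 4-fluorophenyl in place of carboxy on a double-bonded chain carbon bound to a double-bonded chain carbon.

The closest measured evidence is the pair of steps away from compound 1 (an at least 9.7-fold higher number from compound 1 to compound 3 (0.98 log units; beyond the scatter)) and (an at least 9.7-fold higher number from compound 1 to compound 2 (0.98 log units; beyond the scatter)). The remaining step (a step that the two limits leave unreadable from compound 2 to compound 3) adds nothing on size. Within the data shown here, compound 1 is the only measured compound with a ring on this chain, but no measured compound carries the 4-fluorophenyl, so the transfer is uncertain. In this assay a move to a lower number is expected, of a size comparable to those steps in reverse. The expected step is an at least 7.2-fold lower number from compound 3 to compound 4 (0.85 log units; beyond the scatter) in this estimate. Compound 4 is estimated at 6000 nM, with an expected range from 2000 nM to 25000 nM.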

Compound 4, half-maximal effective concentration: > 43400 nM
Compound 4 ended at the assay's limit (the forecaster's own chance of this, stated with the estimate: 20%); middle value at least 7.2-fold (0.85 log units) from the limit.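

In this assay compound 4 gives > 43400 nM, which is a limit of the assay and not a number. A ring on this chain is therefore not enough for a measured effect: the change from benzoyl to 4-fluorophenyl gives an at least 9.7-fold higher number from compound 1 to compound 4 (0.98 log units; beyond the scatter), and benzoyl remains the only group shown here that gives a measured number. The steps to compound 4 from compound 2 and compound 3 cannot be read: the limit of > 43400 nM in this assay, at which 3 of the 4 values shown sit.

Compound 4 loses the carbonyl of compound 1 and gains a fluorine in a single change, and the two remain unseparated. An unsubstituted phenyl or an acetyl group in this place would show whether the ring, the carbonyl or both go with the measured number of compound 1.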